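Replacing pyridin-2-yl with 2-methoxyphenyl in compound 2

The source may hold more compounds than are shown below. What is called first, only, known or untested is meant among the compounds shown, and "the series" means these compounds.

In a functional assay on K562/A02 cells (Homo sapiens) for antiproliferative activity, read by MTT assay (on this read-out higher numbers stand for weaker inhibition and lower numbers for stronger inhibition), compound 1 (`O=C(CCCCCNC(=S)NN=C(c1ccccn1)c1ccccn1)NO`) gives 2180 nM and compound 2 (`O=C(CCCCCNC(=S)N/N=C(\c1ccccc1)c1ccccn1)NO`) gives 2030 nM, two values within the scatter of each other. Compound 3 (`C/C(=N\NC(=S)NCCCCCC(=O)NO)c1ccc(Br)cc1`) gives 440 nM, a lower number that lies beyond the scatter from compound 2. Compound 4 (`COc1ccccc1/C(=N/NC(=S)NCCCCCC(=O)NO)c1ccccc1`) carries 2-methoxyphenyl in place of pyridin-2-yl on a carbon with a double bond to nitrogen. Among the compounds with values here, no measured pair shows this change alone, so in this assay no shift beyond the scatter is expected, with a slight lean towards stronger inhibition. The estimate amounts to an expected 1.4-fold lower number from compound 2 to compound 4 (0.13 log units; within the scatter). Compound 4 is estimated at 1500 nM, with an expected range from 600 nM to 3800 nM.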

Compound 4, half-maximal inhibitory concentration: 2910 nM
Compound 4: middle estimate off by 1.9-fold (0.29 log units), on the low side, within the range that was stated.
By their numbers in this assay, from the lowest: compound 3; then compounds 2, 1 and 4 (each within the scatter of the next).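

Within the data shown here, the first single-place step at this carbon with a double bond to nitrogen is a 1.4-fold higher number from compound 2 to compound 4 (0.16 log units; within the scatter) in this assay, so 2-methoxyphenyl takes the place of pyridin-2-yl with no shift beyond the scatter. On this read-out, the ring nitrogen of pyridin-2-yl is therefore not needed to keep the number in this range. Nothing measured in the data offers an explanation for this outcome. Still open, from the compounds shown here alone, is whether a hydroxyl in place of the methoxy, or an amine or a carboxylic acid on this ring, would move the number beyond the scatter.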